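A Methyl Ester in Place of the Diacid Group

A few compounds are considered here, and "the series" means these few. Any claim that something is new, unique, unknown or untested is made for them only; others in the source may bear on it.

In a functional assay on CCRF-CEM cells (Homo sapiens) for cytotoxicity, in the presence of a further agent that is not named here (a higher number here means a weaker inhibitor, a lower number a stronger inhibitor), compound 3 `Nc1nc(N)c(CCCN(Cc2ccc(NC(CCC(=O)O)C(=O)O)cc2)c2cc(F)ccc2[N+](=O)[O-])c(O)n1` gives > 100000 nM as a limit and not as a number. Going by the values given here, compound 3 thus sits at the limit of > 100000 nM in this assay, at which 1 of the 3 values shown sits, and gives no measured figure to step from.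

Compound 4 `COC(=O)c1ccc(CN(CCCc2c(N)nc(N)nc2O)c2cc(F)ccc2[N+](=O)[O-])cc1` differs from compound 3 in one place: methoxycarbonyl in place of (1,3-dicarboxypropyl)amino on an aromatic carbon, para to a large group (methoxycarbonyl in place of (1,3-dicarboxypropyl)amino on an aromatic carbon). Among the compounds with values here, no measured step makes this exchange. Two measured compounds already carry methoxycarbonyl, compound 1 `COC(=O)c1ccc(CN(CCCc2c(N)nc(N)nc2O)c2cc(F)c([N+](=O)[O-])cc2[N+](=O)[O-])cc1` and compound 2 `COC(=O)c1ccc(CN(CCCc2c(N)nc(N)nc2O)c2cc(F)c(F)cc2[N+](=O)[O-])cc1`. Within the data shown here, the only measured step between them, a 15-fold higher number from compound 1 to compound 2 (1.18 log units; beyond the scatter), is fluoro in place of nitro on an aromatic carbon at another site, so it bears on the question only indirectly, by showing how widely such compounds can spread.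

Given compound 1 at 3500 nM and compound 2 at 53000 nM, a large step towards a lower number, meaning a stronger inhibitor, is expected in this assay for the exchange. The estimated change is an at least 3.3-fold lower number from compound 3 to compound 4 (0.52 log units; beyond the scatter) and it rests on a limit at its starting end. For compound 4 the estimated value is 30000 nM, with an expected range from 7000 nM to 100000 nM in this measurement.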

Compound 4, half-maximal inhibitory concentration: 30000 nM
Beside the measured number, compound 4's estimate shows no gap at the digits printed; measured number inside the range.
By their numbers in this assay, from the lowest: compound 1; then compounds 4 and 2 (each within the scatter of the next). At a limit, above all of these: compound 3.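

Exchanging (1,3-dicarboxypropyl)amino for methoxycarbonyl on this aromatic carbon gives (an at least 3.3-fold lower number from compound 3 to compound 4 (0.52 log units; beyond the scatter)) in this assay, so the exchange can be read only as a bound and not as a size. Compound 4 also adds hydrogen to the nitro and fluoro already seen at the other site among the methoxycarbonyl compounds: the reading (a 1.8-fold lower number from compound 2 to compound 4 (0.25 log units; within the scatter)) leaves fluoro and hydrogen unseparated, while the reading (an 8.6-fold higher number from compound 1 to compound 4 (0.93 log units; beyond the scatter)) sets nitro apart from hydrogen, so nitro alone stands out in this small set. Compound 3 gives a limit and not a number, which is why the first of these steps has an open end: the limit of > 100000 nM in this assay, at which 1 of the 4 values shown sits.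

The compounds shown leave open whether a free carboxylic acid or an amide in place of methoxycarbonyl would read the same, and so whether the exchange depends on methoxycarbonyl itself or simply on the absence of the (1,3-dicarboxypropyl)amino group. They also leave open whether nitro would stand out in the same way with (1,3-dicarboxypropyl)amino kept, and how chloro or an amine would read at the site that carries nitro.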